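Adding a Chlorine to the Phenyl Ring of Compound 2

The source may report more compounds than this note shows. Statements on the series, on what has been measured and on what is new or still open speak of the compounds shown alone.

Compound 1 `COc1ccc(C2CC(c3ccc(Cl)cc3)=NN2c2nc(-c3ccccc3)c(C#N)c(=O)n2C)cc1` and compound 2 `COc1ccc(C2=NN(c3nc(-c4ccccc4)c(C#N)c(=O)n3C)C(c3ccc(OC)cc3)C2)cc1` share one core. In a functional assay on A549 cells (Homo sapiens) for antiproliferative activity, with a stated time of 72 h (on this read-out higher numbers stand for weaker inhibition and lower numbers for stronger inhibition), compound 1 gives 6070 nM, while compound 2 gives 26500 nM, the higher of the two numbers. For the measured compounds named here, the one measured step, a 4.4-fold higher number from compound 1 to compound 2 (0.64 log units; beyond the scatter), shows that methoxy in place of chloro on one aryl ring weakened inhibition. Compound 3 `COc1ccc(C2=NN(c3nc(-c4ccc(Cl)cc4)c(C#N)c(=O)n3C)C(c3ccc(OC)cc3)C2)cc1` differs from compound 2 by chloro in place of hydrogen on an aromatic carbon, on a different ring, so that step bears only loosely. A small drop in the number is expected; the expected step is a 1.8-fold lower number from compound 2 to compound 3 (0.25 log units; within the scatter). Compound 3 is estimated at 15000 nM, with a range from 5000 nM to 50000 nM.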

Compound 3, half-maximal inhibitory concentration: 39700 nM
Compound 3: the middle estimate sits 2.6-fold (0.42 log units) below what was measured; the range from low to high includes it.
By their numbers in this assay, from the lowest: compound 1; then compounds 2 and 3 (each within the scatter of the next).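

Going from phenyl to 4-chlorophenyl at this position gives a 1.5-fold higher number from compound 2 to compound 3 (0.18 log units; within the scatter) in this assay, so chloro in place of hydrogen here leaves compound 2 and compound 3 indistinguishable. The earlier step, on a different ring, lay beyond the scatter, whereas this one does not. Nothing measured here offers an explanation for this result.

Still open, as far as these compounds go, is whether a different group at this position, such as an amine or a carboxylic acid, would shift the number beyond the scatter. Also open, from the compounds shown here alone, is whether chloro here would give a similar result with the chloro of compound 1 on the other ring.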